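A few compounds are considered here, and "the series" means these few. Any claim that something is new, unique, unknown or untested is made for them only; others in the source may bear on it.

Three compounds of one family were tested in a functional assay on T47D cells (Homo sapiens) for inhibition, read by sulforhodamine B assay, with a stated time of 48 h; on this read-out lower numbers stand for higher toxicity in this test and higher numbers for lower toxicity in this test. Compound 1 `O=C(Nc1cccc(-n2cc(-c3ccncc3)c(-c3ccc(Cl)c(O)c3)n2)c1)Nc1ccc(Cl)c(Cl)c1` reaches only the assay limit of > 32500 nM in this assay, so no number is known for it. Compound 3 `O=C(Nc1cccc(-n2cc(-c3ccncc3)c(-c3ccc(Cl)c(O)c3)n2)c1)Nc1cc(C(F)(F)F)cc(C(F)(F)F)c1` likewise stops at the limit of > 50000 nM in this assay. Compound 2 `COc1cc(-c2nn(-c3cccc(NC(=O)c4ccc(Cl)c(C(F)(F)F)c4)c3)cc2-c2ccncc2)ccc1Cl` also shows only the limit of > 32500 nM in this assay. Thus every value given so far is a limit rather than a number: compound 2 stands together with compound 1 at the limit of > 32500 nM in this assay, at which 2 of the 3 values shown sit, while compound 3 sits at the limit of > 50000 nM in this assay, at which 1 of the 3 values shown sits, and none of the three shows measurable toxicity in this test.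

Compound 4 `COc1cc(-c2nn(-c3cccc(NC(=O)Nc4cccc(C(F)(F)F)c4)c3)cc2-c2ccncc2)ccc1Cl` has not yet been measured. It differs from compound 2 in one place: (3-(trifluoromethyl)phenyl)amino in place of 4-chloro-3-(trifluoromethyl)phenyl on a carbonyl carbon. Going by the values given here, no measured pair shows this change, so its effect cannot be read from the data. The expected step that the limit leaves unreadable from compound 2 to compound 4 is none beyond the scatter, and the likeliest outcome is again a limit. Because compound 2 sits at the limit of > 32500 nM in this assay, at which 2 of the 3 values shown sit, compound 4 is expected to give about 40000 nM in this assay, estimated to fall between 15000 nM and 100000 nM.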

Compound 4, concentration lethal to 50% of the cells: 50000 nM
Compound 4: middle estimate off by 1.3-fold (0.10 log units), on the low side; measured number inside the range.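

Going by these compounds alone, compound 4 now has a measured number, whereas compound 2 has only a limit, and no step from compound 2 to compound 4 can be read. The compounds shown leave open whether (3-(trifluoromethyl)phenyl)amino in place of 4-chloro-3-(trifluoromethyl)phenyl on a carbonyl carbon changes the result in this assay at all.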